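Working notes on the series: from compound 3 to compound 4

This account rests on a few compounds, and the source may have more. Where it says the series, first, only, none or still open, it means among the compounds named here.

Measured so far in a functional assay on MDA-MB-468 cells (Homo sapiens) for inhibition, read by sulforhodamine B assay, with a stated time of 48 h, tested at 10 uM; a higher number here means more inhibition at the concentration tested (going by the name of the read-out), a lower number less inhibition:
compound 1 `Fc1ccc(-c2cn3ccnc3c(-c3ccc4ncn(C5CCCCC5)c4c3)n2)cc1`: 19.5%
compound 2 `c1cn2cc(-c3ccsc3)nc(-c3ccc4ncn(C5CCCCC5)c4c3)c2n1`: 21.8%
compound 3 `Fc1ccccc1-c1cn2ccnc2c(-c2ccc3ncn(C4CCCCC4)c3c2)n1`: 27.6%

Compound 3 holds the highest of the three numbers, yet a number 8.1 percentage points higher from compound 1 to compound 3 (within the scatter) and a number 5.8 percentage points higher from compound 2 to compound 3 (within the scatter) are both within the scatter, so the three compounds are not separated by this assay.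

Compound 4 `c1csc(-c2cn3ccnc3c(-c3ccc4ncn(C5CCCCC5)c4c3)n2)c1` differs from compound 3 by thiophen-2-yl in place of 2-fluorophenyl on an aromatic carbon. The step that bears most directly on this exchange is a number 5.8 percentage points higher from compound 2 to compound 3 (within the scatter), which swapped a thiophenyl for a fluorophenyl at the same place and stayed within the scatter; a number 2.3 percentage points higher from compound 1 to compound 2 (within the scatter), another such swap, was likewise within the scatter. No step beyond the scatter is therefore expected: a number 4.6 percentage points lower from compound 3 to compound 4 (within the scatter) is the estimated shift. Compound 4 is expected to give 23%, in the range 11% to 35%.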

Compound 4, a percentage reported as inhibition, at one concentration (the size of the read-out at that concentration, not a potency): 15.1%
The estimate for compound 4 lay 7.9 percentage points above the measured number; low and high end bracket the measured number.
By their numbers in this assay, from the lowest: compounds 4, 1, 2 and 3 (each within the scatter of the next, the first and the last beyond it).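

a number 12.5 percentage points lower from compound 3 to compound 4 (beyond the scatter) in this assay is the first step in the series beyond the scatter, which shows that exchanging the aromatic group at this position can register in this read-out. By contrast, a number 6.7 percentage points lower from compound 2 to compound 4 (within the scatter) and a number 4.4 percentage points lower from compound 1 to compound 4 (within the scatter) stay within it, so thiophen-2-yl is separated only from 2-fluorophenyl. Nothing available here accounts for that single separation.

From the compounds shown here alone, all four compounds carry an aromatic ring at this position, so it remains open how a non-aromatic group, such as an amine or a carboxylic acid, would read there.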